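Bromo in Place of Chloro on a Urea Series

The source may report more compounds than this note shows. Statements on the series, on what has been measured and on what is new or still open speak of the compounds shown alone.

Measured so far in an ADME assay on the whole organism with Oryza sativa as the target, tested at 0.1 uM; on this read-out lower numbers stand for a stronger effect and higher numbers for a weaker effect at the one concentration tested:
compound 1 `C[C@@H](NC(=O)Nc1ccccc1C(C)(C)C)c1ccccc1` gives 100%
compound 2 `C[C@@H](NC(=O)Nc1ccccc1C(F)(F)F)c1ccccc1` gives 99%
compound 3 `C[C@@H](NC(=O)Nc1ccccc1Cl)c1ccccc1` gives 101%

Compound 3 carries the highest number of the three, but only by a little: the step of a number 1 percentage points higher from compound 1 to compound 3 (within the scatter) and the step of a number 2 percentage points higher from compound 2 to compound 3 (within the scatter) both lie within the scatter, as does a number 1 percentage points lower from compound 1 to compound 2 (within the scatter). All three compounds therefore read the same within the noise of this assay.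

Compound 4 `C[C@@H](NC(=O)Nc1ccccc1Br)c1ccccc1` is not yet measured. It differs from compound 3 by bromo in place of chloro on an aromatic carbon. The bearing steps all change the group on the same aromatic carbon, and none of them moved the read-out beyond the scatter. The estimated step of a number 1 percentage points lower from compound 3 to compound 4 (within the scatter) is therefore expected to be none beyond the scatter. Compound 4 is expected to give about 100%, between 90% and 108%.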

Compound 4, a percentage reported as activity, at one concentration (the size of the read-out at that concentration, not a potency): 99%
The estimate for compound 4 lay 1 percentage points above the measured number; the measured number falls inside the stated range.
By their numbers in this assay, from the lowest: compounds 2, 4, 1 and 3 (each within the scatter of the next).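

The steps of a number 2 percentage points lower from compound 3 to compound 4 (within the scatter) and no change at the digits printed from compound 2 to compound 4 (within the scatter) and a number 1 percentage points lower from compound 1 to compound 4 (within the scatter) all stay small in this assay. Swapping one halogen for the other on this aromatic carbon therefore leaves the read-out as flat as the earlier swaps did, and all four groups read alike at the one concentration tested. Nothing available here explains this flat result.

From the compounds shown here alone, whether an amine or a carboxylic acid on this carbon would read differently remains open. So does whether these four compounds would separate at other concentrations.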